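Vinyl to chloromethyl on a carbonyl carbon

The source may hold more compounds than are shown below. What is called first, only, known or untested is meant among the compounds shown, and "the series" means these compounds.

Measured so far in a functional assay on HepG2 cells (Homo sapiens) for cytotoxicity, read by MTT assay; on this read-out higher numbers stand for weaker inhibition and lower numbers for stronger inhibition:
compound 1 `CCCCC(=O)Oc1cc(/C=C/C(=O)c2ccc(OC)c3c2OC(C)(C)C=C3)ccc1OC` gives 100 nM
compound 2 `C=CC(=O)Oc1cc(/C=C/C(=O)c2ccc(OC)c3c2OC(C)(C)C=C3)ccc1OC` gives 160 nM

Compound 2 at 160 nM lies within the scatter of compound 1. Compound 3 `COc1ccc(/C=C/C(=O)c2ccc(OC)c3c2OC(C)(C)C=C3)cc1OC(=O)CCl` has chloromethyl in place of vinyl on a carbonyl carbon and remains unmeasured. Within the data shown here, one measured step bears on this place, a 1.6-fold higher number from compound 1 to compound 2 (0.20 log units; within the scatter), and it stayed within the scatter. A similarly small change, in no particular direction, is therefore expected in this assay. The expected size is a 1.2-fold lower number from compound 2 to compound 3 (0.09 log units; within the scatter) and nothing beyond the scatter. Compound 3 is expected at 130 nM with 45 nM to 400 nM as the estimated range.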

Compound 3, half-maximal inhibitory concentration: 120 nM
Compound 3: middle estimate off by 1.1-fold (0.03 log units), on the high side; the measured number falls inside the stated range.
By their numbers in this assay, from the lowest: compounds 1, 3 and 2 (each within the scatter of the next).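

In this assay, replacing vinyl with chloromethyl on this carbonyl carbon removes the double bond and brings in a chlorine, yet the step stays within the scatter (a 1.3-fold lower number from compound 2 to compound 3 (0.12 log units; within the scatter)). Compared with the butyl ester, the chloromethyl ester also stays within the scatter (a 1.2-fold higher number from compound 1 to compound 3 (0.08 log units; within the scatter)), so all three groups tested here give values that cannot be told apart. No evidence is available to explain this result.

From the compounds shown here alone, whether an amine, a carboxylic acid or a longer chain at this place would give a step beyond the scatter remains open. The compounds shown also leave open how changes elsewhere on the shared core would read.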